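The source may report more compounds than this note shows. Statements on the series, on what has been measured and on what is new or still open speak of the compounds shown alone.

Measured so far in a functional assay on HCT-116 cells (Homo sapiens) for antiproliferative activity, read by MTT assay, with a stated time of 48 h; a lower number here means a stronger inhibitor, a higher number a weaker inhibitor:
compound 1 `COc1ccc(-c2cc3c(cn2)[nH]c(=O)n3-c2cc(OC)c(OC)c(OC)c2)cc1F`: 910 nM
compound 2 `CCOc1ccc(-c2cc3c(cn2)[nH]c(=O)n3-c2cc(OC)c(OC)c(OC)c2)cc1`: 6660 nM

Of these two, compound 2 has the higher number and is therefore the weaker inhibitor. The next compound, compound 3 `COc1ccc(-c2cc3c(cn2)[nH]c(=O)n3-c2cc(OC)c(OC)c(OC)c2)cc1C`, differs from compound 2 in one place: 4-methoxy-3-methylphenyl stands in place of 4-ethoxyphenyl on an aromatic carbon 4-methoxy-3-methylphenyl in place of 4-ethoxyphenyl on an aromatic carbon and the atoms are the same but joined differently.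

Among the compounds with values here, only one measured step bears on this change. It is a 7.3-fold higher number from compound 1 to compound 2 (0.86 log units; beyond the scatter), a modest step beyond the scatter, in which 4-ethoxyphenyl replaced 3-fluoro-4-methoxyphenyl. The group in compound 3 keeps the 4-methoxy of compound 1 and loses the 4-ethoxy of compound 2, with methyl where compound 1 has fluoro. One step is thin evidence, and the effect of methyl here is unmeasured. Even so, a move back toward the lower number seems likely, though probably not all the way.

The expected change is a 3.7-fold lower number from compound 2 to compound 3 (0.57 log units; beyond the scatter) in this assay and is only an estimate. For compound 3 the estimated value is 1800 nM with an expected range from 600 nM to 5500 nM at the two ends.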

Compound 3, half-maximal inhibitory concentration: 1810 nM
For compound 3 the middle estimate is 1.0-fold (0.00 log units) below the measured one; the measured number falls inside the stated range.
By their numbers in this assay, from the lowest: compounds 1 and 3 (each within the scatter of the next); then compound 2.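

In this assay the two groups on this aromatic carbon hold the same atoms, yet 4-methoxy-3-methylphenyl in place of 4-ethoxyphenyl gives a 3.7-fold lower number from compound 2 to compound 3 (0.57 log units; beyond the scatter) and so the way those atoms are arranged matters at this position, not just how many there are. Methyl in place of fluoro gives a 2.0-fold higher number from compound 1 to compound 3 (0.30 log units; within the scatter) and so this pair offers no ground for separating the two groups in this assay, which means the methyl compound sits with the fluoro compound and apart from the ethoxy one. Nothing available explains why the 4-ethoxyphenyl group goes with the higher number.

The compounds shown leave open what the methoxy group does with no second group on the ring, as in plain 4-methoxyphenyl, and whether 3-chloro-4-methoxyphenyl or 3-amino-4-methoxyphenyl would stay with compound 1 and compound 3. They also leave open whether a longer chain such as 4-propoxyphenyl would move the number further in the direction seen with compound 2.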